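One Double Bond Flipped in a Long-Chain Amide

The compounds below may be only part of what the source reports. "The series", "measured", "known", "first", "only" and "open" are said of these compounds alone.

Measured so far:
Compound 1, `CC/C=C/C/C=C\CC/C=C/C=C/C(=O)NCC(C)(C)O`, gives 4% in a functional assay on cells (Platelet, Oryctolagus cuniculus) for inhibition, read by turbidimetry, with a stated time of 3 min, tested at 20 ug/mL; a higher number here means a weaker effect of the compound at the concentration tested, a lower number a stronger effect.
Compound 2, `COc1ccc(-c2oc3c(OC)c(O)cc(O)c3c(=O)c2O)cc1`, gives 0% in this assay.
Compound 3, `CCC(=O)CC/C=C\CC/C=C/C=C/C(=O)NCC(C)C`, gives 0% in this assay.

In this assay compound 1 stands highest of the three numbers, yet the values of compound 2 and compound 3 lie within the scatter of it, so the three compounds cannot be told apart on these data. Compound 4, `CC/C=C\C/C=C\CC/C=C/C=C/C(=O)NCC(C)(C)O`, has not been measured. Its difference from compound 1 is small: the two compounds have the same atoms and bonds and differ only in configuration as drawn: 1 of 4 stereo elements differ; a double bond is drawn E in compound 1 and Z in compound 4. Going by the values given here, no pair of measured compounds shows the effect of such a change, and all three values sit near the bottom of the scale. For compound 4 the expected step is no change at the digits printed from compound 1 to compound 4 (within the scatter), no larger than the scatter, in no particular direction. Compound 4 is therefore estimated at 4%, within a range from 0% to 15%.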

Compound 4, a percentage reported as activity, at one concentration (the size of the read-out at that concentration, not a potency): 4%
Compound 4: the middle estimate sits on the measured number at the digits printed; measured number inside the range.
By their numbers in this assay, from the lowest: compounds 2, 3, 1 and 4 (each within the scatter of the next).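

In this assay, going by these compounds alone, changing this double bond from E to Z gives no change at the digits printed from compound 1 to compound 4 (within the scatter), the first step here that isolates a single change. At this position, the drawn geometry of the double bond leaves the read-out unchanged at the concentration tested, and the comparison is direct: the fact that compounds 1 and 4 differ only in the configuration as drawn.

Still open, on these data alone, is whether the other double bonds in the chain would tolerate the same change. Also open, as far as these compounds go, is whether a carboxylic acid or an amine in place of the hydroxyl group would move the number at all.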